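The source may report more compounds than this note shows. Statements on the series, on what has been measured and on what is new or still open speak of the compounds shown alone.

Measured so far in a functional assay on HepG2 cells (Homo sapiens) for inhibition, read by MTT assay, with a stated time of 48 h; a higher number here means a weaker inhibitor, a lower number a stronger inhibitor:

compound 1, `COc1cc(/C=N/Nc2nc(-c3ccccc3)cs2)c(Br)c(Br)c1OC`, 33600 nM
compound 2, `Fc1ccc(/C=N/Nc2nc(-c3ccc(Br)cc3)cs2)cc1F`, > 100000 nM
compound 3, `COc1cc(/C=N/Nc2nc(-c3cccc(Br)c3)cs2)c(Br)c(Br)c1OC`, > 100000 nM

For the measured compounds named here, compound 1 is the only member of the set with a numerical reading; in this assay compound 1 gives 33600 nM. For compound 2 the reading is a limit of the assay and not a number, > 100000 nM. For compound 3 the reading is likewise a limit, > 100000 nM. The limit is the one described in the limit of > 100000 nM in this assay, at which 2 of the 3 values shown sit.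

One change can be followed between measured compounds. Compound 3 and compound 1 share a core and differ by hydrogen in place of bromo on an aromatic carbon; the step is an at least 2.9-fold lower number from compound 3 to compound 1 (0.47 log units; beyond the scatter), so taking the bromo off the 3-bromophenyl is at least a modest gain.

Compound 4, `Fc1ccc(/C=N/Nc2nc(-c3ccccc3)cs2)cc1F`, is not yet measured. It relates to compound 2 by hydrogen in place of bromo on an aromatic carbon. Going by the values given here, this is the same kind of change as the one from compound 3 to compound 1, but not the same: in that pair the leaving bromo sits meta to a large group, here it sits para to a large group, and the cores of compound 2 and compound 3 also differ, a difference that is not broken down here.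

Resting on the step seen from compound 3 to compound 1, an at least 2.9-fold lower number from compound 3 to compound 1 (0.47 log units; beyond the scatter), a gain of similar size is expected from compound 2 to compound 4, roughly an at least 1.6-fold lower number from compound 2 to compound 4 (0.22 log units; that floor lies within the scatter); but the starting point is a limit, so the true size is uncertain. In this assay compound 4 is estimated at 60000 nM, expected between 15000 nM and 200000 nM, with a real chance that only a limit is reported again.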

Compound 4, half-maximal inhibitory concentration: > 100000 nM
Compound 4: only a limit was reported; the forecaster's own chance of this, stated with the estimate: 40%; at least 1.6-fold (0.22 log units) between middle value and limit.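

In this assay compound 4 reads > 100000 nM, a limit and not a number. Compound 2 stands at the same limit, so the change from 4-bromophenyl to phenyl between compound 2 and compound 4 gives no readable step: the limit of > 100000 nM in this assay, at which 3 of the 4 values shown sit.

Still open, from the compounds shown here alone, is whether taking off the bromo changes the reading at all in the core of compound 4, as it does between compound 3 and compound 1.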